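Pyrazoline sulfonamides in a rat paw edema assay

The compounds below may be only part of what the source reports. "The series", "measured", "known", "first", "only" and "open" are said of these compounds alone.

Three pyrazoline sulfonamides have been measured in a functional assay on the whole organism (strain Wistar albino) for inhibition, with Rattus norvegicus as the target, read by paw edema, with stated times of 30 min and 3 h, at a dose of 0.05 mmol/kg; on this read-out higher numbers stand for more inhibition at the one dose given (going by the name of the read-out) and lower numbers for less inhibition. Compound 1 `Cc1ccc([C@@H]2CC(c3cccc(O)c3)=NN2c2ccc(S(N)(=O)=O)cc2)cc1` gives 64.7%, and compound 2 `NS(=O)(=O)c1ccc(N2N=C(c3cccc(O)c3)C[C@H]2c2ccc(O)cc2)cc1` gives 64.7%, so that no change at the digits printed from compound 1 to compound 2 (within the scatter). Compound 3 `NS(=O)(=O)c1ccc(N2N=C(c3cccc(O)c3)C[C@H]2c2ccccc2O)cc1` gives 35.4%, the lowest of the three numbers: a number 29.3 percentage points lower from compound 1 to compound 3 (beyond the scatter), and a number 29.3 percentage points lower from compound 2 to compound 3 (beyond the scatter). Both measured steps therefore concern the group on the saturated ring carbon and show that exchanging the aryl group there can move the read-out by a modest amount.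

Compound 4 `NS(=O)(=O)c1ccc(N2N=C(c3cccc(O)c3)C[C@H]2/C=C/c2ccccc2)cc1` is not yet measured. It differs from compound 3 as follows: 2-phenylethenyl in place of 2-hydroxyphenyl on a saturated ring carbon. Among the compounds with values here, no measured compound carries a 2-phenylethenyl group, so the direction is uncertain, but the two modest drops into compound 3 suggest that leaving the 2-hydroxyphenyl group behind could recover part of the inhibition. Compound 4 is therefore expected to show a modest rise, a number 16.6 percentage points higher from compound 3 to compound 4 (beyond the scatter), and its value in this assay is estimated at 52%, within a range of 32% to 72%.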

Compound 4, a percentage reported as inhibition, in the whole organism at one dose (the size of the read-out at that dose, not a potency): 39.9%
Beside the measured number, compound 4's estimate is 12.1 percentage points above it; measured number inside the range.
By their numbers in this assay, from the lowest: compounds 3 and 4 (each within the scatter of the next); then compounds 1 and 2 (each within the scatter of the next).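

In this assay the exchange of 2-hydroxyphenyl for 2-phenylethenyl gives a number 4.5 percentage points higher from compound 3 to compound 4 (within the scatter) and so leaves the read-out unresolved between these two groups, although 2-phenylethenyl carries a double bond outside aromatic rings and has no hydrogen-bond donors or acceptors. The same group gives a number 24.8 percentage points lower from compound 2 to compound 4 (beyond the scatter) and also a number 24.8 percentage points lower from compound 1 to compound 4 (beyond the scatter) so the lower level at this saturated ring carbon is not confined to the 2-hydroxyphenyl group, and it now appears with a group that has no hydroxy at all. Nothing available here bears on the reason for this result.

The compounds shown leave open which feature shared by 4-hydroxyphenyl and 4-methylphenyl goes with the higher numbers. They also leave open how a saturated 2-phenylethyl chain, an amine or a carboxylic acid at this carbon would read out.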